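A longer chain on compound 3

The source may hold more compounds than are shown below. What is called first, only, known or untested is meant among the compounds shown, and "the series" means these compounds.

Compound 1 `CCCCCCCCCC(=O)N[C@@H](CCCNC(=N)N)C(=O)Nc1ccn([C@H]2O[C@@H](CO)[C@H](O)[C@H]2O)c(=O)n1` gives 6000 nM
Compound 2 `CCCCCCCCCC(=O)N[C@@H](CCC(=O)O)C(=O)Nc1ccn([C@H]2O[C@@H](CO)[C@H](O)[C@H]2O)c(=O)n1` gives 5000 nM
Compound 3 `CCCCCCCCCC(=O)N[C@@H](CCSC)C(=O)Nc1ccn([C@H]2O[C@@H](CO)[C@H](O)[C@H]2O)c(=O)n1` gives 3000 nM

These values come from a functional assay on HeLa cells (Homo sapiens) for cytotoxicity, read by MTT assay, with a stated time of 48 h (on this read-out lower numbers stand for stronger inhibition and higher numbers for weaker inhibition), and sit close together. The data show a 2.0-fold lower number from compound 1 to compound 3 (0.30 log units; within the scatter) and a 1.7-fold lower number from compound 2 to compound 3 (0.22 log units; within the scatter), so compound 3 cannot be told apart from the other two.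

Compound 4 `CCCCCCCCCCCCCC(=O)N[C@@H](CCSC)C(=O)Nc1ccn([C@H]2O[C@@H](CO)[C@H](O)[C@H]2O)c(=O)n1` has not yet been measured. Its difference from compound 3 is butyl in place of hydrogen on a saturated chain carbon, nine bonds along the chain from a carbonyl carbon. Read another way, this is methyl to pentyl, so the chain grows longer.

For the measured compounds named here, none of the measured steps involves this change. Besides the two above, the only other is a 1.2-fold lower number from compound 1 to compound 2 (0.08 log units; within the scatter). All three alter a different group, three bonds along the chain from an amide-type nitrogen and a carbonyl carbon. Going by the values given here, they therefore give neither a size nor a direction for the new change, and no compound here shows what chain length does. With no evidence for a shift, no step beyond the scatter is expected, and the estimate starts from compound 3 at 3000 nM in this assay. The expected step is no change at the digits printed from compound 3 to compound 4 (within the scatter). Going by these compounds, the range is kept wide because the change is untested. Compound 4 is estimated at 3000 nM, with an expected range from 1000 nM to 9000 nM.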

Compound 4, half-maximal inhibitory concentration: 8020 nM
For compound 4 the middle estimate is 2.7-fold (0.43 log units) below the measured one; the measured number falls inside the stated range.
By their numbers in this assay, from the lowest: compounds 3, 2, 1 and 4 (each within the scatter of the next, the first and the last beyond it).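

Until now, every step changed the group three bonds along the chain from an amide-type nitrogen and a carbonyl carbon, and each stayed within the scatter. The new change sits elsewhere, on a saturated chain carbon, nine bonds along the chain from a carbonyl carbon, and in this assay butyl in place of hydrogen there gives a 2.7-fold higher number from compound 3 to compound 4 (0.43 log units; beyond the scatter), a modest step but one beyond the scatter, so the longer chain goes with weaker inhibition in this single pair and the length of this chain can move the number. Nothing available explains the rise.

This is one comparison of two chain lengths, so it cannot show whether the number climbs steadily with length or whether a shorter chain, such as one ending in hexyl in place of pentyl, or a still longer chain would follow the same direction. Also open, going by these compounds, is whether an amine or a carboxylic acid at the end of this chain would shift the number as butyl does, and whether the same lengthening would give a similar step on compound 1 or compound 2.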